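Triazole carboxamide series: aryl swap on the ring nitrogen

The source may report more compounds than this note shows. Statements on the series, on what has been measured and on what is new or still open speak of the compounds shown alone.

Measured so far:
compound 1 `COc1cc2c(Oc3ccc(NC(=O)c4nnn(-c5ccccc5C(F)(F)F)c4C(F)(F)F)cc3F)ccnc2cc1OCCCN1CCCC1` — 60 nM
compound 2 `COc1cc2c(Oc3ccc(NC(=O)c4nnn(-c5ccc(C)cc5)c4C(F)(F)F)cc3F)ccnc2cc1OCCCN1CCC(C)CC1` — 140 nM

Going by the values given here, in a functional assay on MKN-45 cells (Homo sapiens) for cytotoxicity, read by MTT assay, with a stated time of 72 h (on this read-out lower numbers stand for stronger inhibition and higher numbers for weaker inhibition), compound 2 gives the highest of the two numbers so far; compound 1 sits beyond the scatter from it on the lower side. Compound 3 `COc1cc2c(Oc3ccc(NC(=O)c4nnn(-c5ccccc5C(F)(F)F)c4C(F)(F)F)cc3F)ccnc2cc1OCCCN1CCC(C)CC1` has not yet been measured in this assay. It differs from compound 2 in one place: 2-(trifluoromethyl)phenyl in place of 4-methylphenyl on an aromatic nitrogen. The same 2-(trifluoromethyl)phenyl group on the aromatic nitrogen is found in compound 1, which gives 60 nM in this assay. On that basis the step from compound 2 to compound 3 is expected to move the number down, by roughly the size seen between the two measured compounds, though a result within the scatter of compound 2 cannot be ruled out: a 1.8-fold lower number from compound 2 to compound 3 (0.24 log units; within the scatter) is the expected step. Compound 3 is therefore estimated at 80 nM in this assay, within a range of 35 nM to 200 nM.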

Compound 3, half-maximal inhibitory concentration: 100 nM
The estimate for compound 3 lay 1.3-fold (0.10 log units) below the measured number; low and high end bracket the measured number.
By their numbers in this assay, from the lowest: compounds 1, 3 and 2 (each within the scatter of the next, the first and the last beyond it).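

In this assay the aryl swap on the aromatic nitrogen gives a 1.4-fold lower number from compound 2 to compound 3 (0.15 log units; within the scatter) with the 4-methylpiperidin-1-yl end held fixed, so 2-(trifluoromethyl)phenyl and 4-methylphenyl are not separated at this position. The series now also has a step at the far end of the side chain: 4-methylpiperidin-1-yl in place of pyrrolidin-1-yl gives a 1.7-fold higher number from compound 1 to compound 3 (0.22 log units; within the scatter) with 2-(trifluoromethyl)phenyl held fixed, and that change is not resolved either. Nothing at hand speaks to the reason for either result.

Still open, as far as these compounds go, is how 4-methylphenyl reads with the pyrrolidin-1-yl end, which would test the aryl swap on a second side chain. Also open, from the compounds shown here alone, is whether an aryl ring carrying a nitrile or a carboxylic acid, or a morpholine end on the chain, would move the number beyond the scatter.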